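Isopropyl to propyl on an amine nitrogen

The source may report more compounds than this note shows. Statements on the series, on what has been measured and on what is new or still open speak of the compounds shown alone.

For the measured compounds named here, in an ADME assay on microsomes from liver (Mus musculus) for metabolic stability, read by LC-MS, with a stated time of 10 min (a lower number here means that less of the compound is left, a higher number that more of the compound is left), compound 2 `CC(C)N(C[C@H]1Cc2c(cccc2N2CCNCC2)CN1)[C@H]1CCCc2cccnc21` gives 91% and stands highest of the two numbers so far, while compound 1 `FC1(F)CCC(CN(C[C@H]2Cc3c(cccc3N3CCNCC3)CN2)[C@H]2CCCc3cccnc32)CC1` gives 76.6% and stands lower. Compound 3 `CCCN(C[C@H]1Cc2c(cccc2N2CCNCC2)CN1)[C@H]1CCCc2cccnc21` is not yet measured and carries propyl in place of isopropyl on an amine nitrogen. Going by the values given here, the only measured step that bears on this is a number 14.4 percentage points higher from compound 1 to compound 2 (beyond the scatter) and it replaced (4,4-difluorocyclohexyl)methyl, a much bigger swap than this one. A small expected drop of a number 7 percentage points lower from compound 2 to compound 3 (within the scatter) in this assay would stay within the scatter. Compound 3 is estimated at 84% (range 70% to 95%).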

Compound 3, percent of the compound remaining: 87.4%
Estimate against measurement, compound 3: 3.4 percentage points below; low and high end bracket the measured number.
By their numbers in this assay, from the lowest: compound 1; then compounds 3 and 2 (each within the scatter of the next).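

In this assay, exchanging isopropyl for propyl on this amine nitrogen gives a number 3.6 percentage points lower from compound 2 to compound 3 (within the scatter), so this measurement does not separate the two groups. Like isopropyl, propyl stays clear of the (4,4-difluorocyclohexyl)methyl compound, with a number 10.8 percentage points higher from compound 1 to compound 3 (beyond the scatter) on that comparison. No measurement shown here explains these numbers. Still open, from the compounds shown here alone, is how a longer chain such as butyl, a small ring such as cyclopropyl, or a chain ending in a hydroxyl group would fare on this nitrogen.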